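This account rests on a few compounds, and the source may have more. Where it says the series, first, only, none or still open, it means among the compounds named here.

Of the compounds shown here, three sharing one core have been measured in a functional assay on FM3A cells (Mus musculus) for inhibition, read by cell counting, with a stated time of 2 days; on this read-out higher numbers stand for weaker inhibition and lower numbers for stronger inhibition. Compound 1, `C=C(Br)C(=O)Nc1cccc(-c2cn3nc(-c4ccc(OC)c(OC)c4)sc3n2)c1`, gives 110 nM. Compound 2, `C=C(Br)C(=O)Nc1cccc(-c2cn3nc(-c4ccc(C)cc4)sc3n2)c1`, gives 1200 nM, and compound 3, `C=C(Br)C(=O)Nc1cccc(-c2cn3nc(Cc4cccc(OC)c4)sc3n2)c1`, gives 1100 nM. Among these three numbers compound 3 stands second highest: one step, a 1.1-fold lower number from compound 2 to compound 3 (0.04 log units; within the scatter), lies within the scatter, while the other, a 10-fold higher number from compound 1 to compound 3 (1.00 log units; beyond the scatter), lies well beyond it.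

Compound 4, `C=C(Br)C(=O)Nc1cccc(-c2cn3nc(Cc4ccc(OC)cc4)sc3n2)c1`, is built from the same atoms as compound 3, joined differently: 4-methoxyphenyl in place of 3-methoxyphenyl on a saturated chain carbon bound to an aromatic carbon. Going by the values given here, no measured step turns a 3-methoxybenzyl group into a 4-methoxybenzyl group, so this change has no direct precedent. The two steps that come closest both start from compound 1: an 11-fold higher number from compound 1 to compound 2 (1.04 log units; beyond the scatter) and a 10-fold higher number from compound 1 to compound 3 (1.00 log units; beyond the scatter). Both of these large shifts accompany the replacement of the whole 3,4-dimethoxyphenyl group, whereas compound 2 and compound 3, which differ in the entire group attached to the core, sit within the scatter of each other. Compound 4 is therefore expected to show only a step within the scatter, a 1.1-fold lower number from compound 3 to compound 4 (0.04 log units; within the scatter). Compound 4 is thus expected to give about 1000 nM in this assay, with a range from 400 nM to 3000 nM.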

Compound 4, half-maximal inhibitory concentration: 850 nM
Estimate against measurement, compound 4: 1.2-fold (0.07 log units) above; low and high end bracket the measured number.
By their numbers in this assay, from the lowest: compound 1; then compounds 4, 3 and 2 (each within the scatter of the next).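

Going by these compounds alone, putting 4-methoxybenzyl in place of 3-methoxybenzyl on the shared core gives a 1.3-fold lower number from compound 3 to compound 4 (0.11 log units; within the scatter) in this assay and so makes no readable difference, which is the first direct look at where the methoxy group sits on the benzyl ring. The 4-methoxybenzyl group also stays level with 4-methylphenyl, at a 1.4-fold lower number from compound 2 to compound 4 (0.15 log units; within the scatter) for that exchange, while replacing 3,4-dimethoxyphenyl with it gives a 7.7-fold higher number from compound 1 to compound 4 (0.89 log units; beyond the scatter) and again lies beyond the scatter, so compounds 2, 3 and 4 now form one group and compound 1 alone stands apart from all three. Nothing available here explains why compound 1 stands apart.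

Compound 1 differs from compound 4 both in its second methoxy group and in lacking the saturated chain carbon, so the compounds shown cannot separate these two changes; a 3,4-dimethoxybenzyl group or a 4-methoxyphenyl group on the same aromatic carbon would begin to do so. From the compounds shown here alone, how a group of another kind, such as an amine or a carboxylic acid on the ring, would read in this assay also remains open.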